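The compounds below may be only part of what the source reports. "The series", "measured", "known", "first", "only" and "open" are said of these compounds alone.

Three compounds share one core and differ mainly in the group carried on a ring nitrogen. Compound 1 `CC(C)=CCC/C(C)=C/CC/C(C)=C/CC[C@@H]1[C@@]2(C)CC/C(=N\OCc3cn(-c4ccc(F)c(Cl)c4)nn3)C(C)(C)[C@@H]2CC[C@@]1(C)O` was tested in a functional assay on DU-145 cells (Homo sapiens) for cytotoxicity, read by MTT assay, with a stated time of 48 h (on this read-out higher numbers stand for weaker inhibition and lower numbers for stronger inhibition), and gave 26900 nM. Compound 2 `COc1cc(OC)c(-n2cc(CO/N=C3\CC[C@]4(C)[C@@H](CC/C=C(\C)CC/C=C(\C)CCC=C(C)C)[C@](C)(O)CC[C@H]4C3(C)C)nn2)c(OC)c1` gave 11100 nM in this assay, and compound 3 `CC(C)=CCC/C(C)=C/CC/C(C)=C/CC[C@@H]1[C@@]2(C)C/C(=C\c3ccc(OCc4cn(-c5ccc(F)cc5)nn4)cc3)C(=O)C(C)(C)[C@@H]2CC[C@@]1(C)O` gave 33600 nM. Compound 3 thus carries the largest of the three numbers; its gap to compound 1 lies within the usual scatter, while compound 2 sits lower by a margin beyond it. Within the data shown here, the only single-point change measured so far is a 2.4-fold lower number from compound 1 to compound 2 (0.38 log units; beyond the scatter), a modest step. The unmeasured compound 4 `CC(C)=CCC/C(C)=C/CC/C(C)=C/CC[C@@H]1[C@@]2(C)C/C(=C\c3ccc(OCc4cn(-c5cccc([N+](=O)[O-])c5)nn4)cc3)C(=O)C(C)(C)[C@@H]2CC[C@@]1(C)O` differs from compound 3 by 3-nitrophenyl in place of 4-fluorophenyl on an aromatic nitrogen. Among the measured compounds shown here, that earlier step concerns a different pair of groups, so it shows only that exchanging the group on this ring nitrogen has moved the number modestly rather than strongly, and nothing measured points to a particular direction here. Compound 4 is therefore expected to show a 1.3-fold lower number from compound 3 to compound 4 (0.13 log units; within the scatter). The estimate for compound 4 is 25000 nM, with an expected range from 10000 nM to 60000 nM.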

Compound 4, half-maximal inhibitory concentration: 46400 nM
Compound 4: the middle estimate sits 1.9-fold (0.27 log units) below what was measured; low and high end bracket the measured number.
By their numbers in this assay, from the lowest: compound 2; then compounds 1, 3 and 4 (each within the scatter of the next).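

Replacing 4-fluorophenyl with 3-nitrophenyl on the aromatic nitrogen gives a 1.4-fold higher number from compound 3 to compound 4 (0.14 log units; within the scatter), so this assay does not separate compound 3 from compound 4. Among these compounds, this position therefore accepts a group with more heavy atoms and with two hydrogen-bond acceptors where the old group had none, without a shift beyond the scatter, whereas the only earlier step at this nitrogen, a 2.4-fold lower number from compound 1 to compound 2 (0.38 log units; beyond the scatter), concerned other groups on a different core and did exceed it. No measurement here explains why this exchange leaves the reading within the scatter.

Because the nitro group differs from fluorine in both identity and ring position, this one pair cannot separate the two changes, and 4-nitrophenyl would be needed to do so. On these data alone, whether an amine or a carboxylic acid on this phenyl ring would move the number beyond the scatter also remains open.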